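The source may report more compounds than this note shows. Statements on the series, on what has been measured and on what is new or still open speak of the compounds shown alone.

Series notes. Among the compounds with values here, compound 1 `Cc1cccc(NC(=O)CCN2CCN(c3ccccn3)CC2)c1` is the only member with a number in a functional assay on cells for agonist activity at D(4) dopamine receptor (Homo sapiens), read by TR-FRET and cAMP accumulation, with a stated time of 30 min; on this read-out lower numbers stand for smaller maximal responses and higher numbers for larger maximal responses: compound 1 gives 30%. Within the data shown here, compound 2 `Cc1ccc(C2CCN(CC(=O)Nc3cccc(C)c3)CC2)nc1` shares the anilide and the saturated six-membered ring but carries a 5-methylpyridin-2-yl group on a saturated ring carbon; in this assay compound 2 is reported as "not active" (no number reported), with no number, so compound 2 stands below anything that can be placed on the scale, and no step from compound 1 to compound 2 can be given.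

Compound 3 `Cc1ccc(C2CCN(CC(=O)Nc3cccc(C)c3)CC2)cc1` is the next member to be measured. It differs from compound 2 in one place: 4-methylphenyl in place of 5-methylpyridin-2-yl on a saturated ring carbon

Among the measured compounds shown here, no step between two measured compounds is available, so the expected size of the move from compound 2 to compound 3 in this assay cannot be anchored; with compound 2 reported as "not active" (no number reported), a move of no more than the usual scatter is expected, in no particular direction. Compound 3 is therefore estimated at 12%, in the range 0% to 35%, with a real chance that this assay again reports no number.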

Compound 3, largest response reached (Emax), in percent of the reference or control that the assay uses: "not active" (no number reported)
Nothing numeric was reported for compound 3; no gap can be computed for the estimate.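

In this assay, within the data shown here, compound 2 and compound 3 both lack a number, so no step between them can be read. The compounds shown leave open whether 4-methylphenyl and 5-methylpyridin-2-yl differ at all in maximal response. No supporting data bear on this result.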